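A few compounds are considered here, and "the series" means these few. Any claim that something is new, unique, unknown or untested is made for them only; others in the source may bear on it.

Compound 1 `COc1ccc(Cc2nnc(NC(=O)/C(C#N)=C/c3ccccc3OS(=O)(=O)c3ccc(C)cc3)s2)cc1`: 70%
Compound 2 `COc1ccc(Cc2nnc(NC(=O)/C(C#N)=C/c3ccccc3OS(=O)(=O)c3ccccc3[N+](=O)[O-])s2)cc1`: 68%

Among the measured compounds shown here, these two values come from a functional assay on RS4-11 cells (Homo sapiens) for inhibition, read by CCK-8 assay, with a stated time of 48 h, tested at 20 uM (on this read-out higher numbers stand for more inhibition of growth at the one concentration tested and lower numbers for less inhibition of growth), and are the only measurements so far. Compound 2 at 68% stands level with compound 1, and the step between them is a number 2 percentage points lower from compound 1 to compound 2 (within the scatter) and nothing larger.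

For the measured compounds named here, the next compound, compound 3 `COc1ccc(Cc2nnc(NC(=O)/C(C#N)=C/c3ccccc3OS(=O)(=O)c3ccc(Cl)cc3)s2)cc1`, keeps the shared core and alters only one group. The change is 4-chlorophenyl in place of 2-nitrophenyl on a sulfonyl sulfur (in words, 4-chlorophenyl in place of 2-nitrophenyl on a sulfonyl sulfur).

Going by the values given here, one measured step bears on this change, since only one other exchange has been tested at the same sulfonyl sulfur. That exchange, 2-nitrophenyl in place of 4-methylphenyl, gave a number 2 percentage points lower from compound 1 to compound 2 (within the scatter) as its whole effect. Among the compounds with values here, a single step is thin evidence, and no compound with 4-chlorophenyl has been measured yet. Even so, no shift beyond the scatter is expected in this assay here. The expected size of the change is a number 1 percentage points higher from compound 2 to compound 3 (within the scatter) by this estimate. For compound 3 the estimated value is 69% with an expected range from 58% to 79% in this measurement.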

Compound 3, percent growth inhibition at one concentration: 79%
Compound 3: the middle estimate sits 10 percentage points below what was measured; measured number inside the range.
By their numbers in this assay, from the lowest: compounds 2, 1 and 3 (each within the scatter of the next, the first and the last beyond it).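

In this assay the sulfonyl sulfur gives its first step beyond the scatter: 4-chlorophenyl in place of 2-nitrophenyl gives a number 11 percentage points higher from compound 2 to compound 3 (beyond the scatter) on this read-out, so the group held on this sulfur can shift growth inhibition to a measurable degree. Among the compounds shown here, the other exchange that brings in compound 3, chloro in place of methyl on an aromatic carbon, gives a number 9 percentage points higher from compound 1 to compound 3 (within the scatter) and does not separate those two compounds, so only one of the three exchanges at this position stands clear of the scatter, and the 4-methylphenyl compound cannot be told apart from either of the others. The data shown offer no measurement that accounts for the gap between the 4-chlorophenyl and 2-nitrophenyl compounds.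

Still open, from the compounds shown here alone, is whether the aromatic ring on the sulfonyl sulfur is needed at all, which a simple methyl or a longer alkyl chain on that sulfur would test. Also open, going by these compounds, is how a phenyl ring carrying an amine or a carboxylic acid would fare, and whether the small gaps seen at this one concentration would hold across a range of concentrations.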